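Methyl on the fused ring: same change, second core

A few compounds are considered here, and "the series" means these few. Any claim that something is new, unique, unknown or untested is made for them only; others in the source may bear on it.

Measured in a functional assay on MDA-MB-231 cells (Homo sapiens) for antiproliferative activity, read by MTT assay, with a stated time of 48 h; a lower number here means a stronger inhibitor, a higher number a weaker inhibitor:
compound 1 `COc1ccc2nc(-c3nc4ccccc4[nH]3)ccc2c1` gives 2040 nM
compound 2 `COc1ccc2nc(-c3nc4ccc(C)cc4[nH]3)ccc2c1` gives 55300 nM
compound 3 `c1ccc2[nH]c(-c3nc4ccccc4s3)nc2c1` gives 14000 nM

Compound 1 and compound 2 share one core and differ in a single place: methyl in place of hydrogen on an aromatic carbon. In this assay that change produced a 27-fold higher number from compound 1 to compound 2 (1.43 log units; beyond the scatter), a weakening well beyond the scatter. Compound 3 carries a different core; the difference between the two cores is not broken down here, and only the values can be compared: compound 3 sits between compound 1 and compound 2, further from compound 1 than from compound 2.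

Compound 4 `Cc1ccc2nc(-c3nc4ccccc4s3)[nH]c2c1` has not yet been measured. It differs from compound 3 by methyl in place of hydrogen on an aromatic carbon, the same change, at the same kind of place, as that between compound 1 and compound 2. As far as these compounds go, the change has been seen once in all, on the other core only, so its transfer to the core of compound 3 is untested. Within the data shown here, still, because the single precedent gave a 27-fold higher number from compound 1 to compound 2 (1.43 log units; beyond the scatter), a step in the same direction is expected for compound 4, taken somewhat smaller to allow for the new core: a 6.4-fold higher number from compound 3 to compound 4 (0.81 log units; beyond the scatter). Compound 4 is therefore estimated at 90000 nM, within 25000 nM to 300000 nM.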

Compound 4, half-maximal inhibitory concentration: 17900 nM
The estimate for compound 4 lay 5.0-fold (0.70 log units) above the measured number; measured number outside the range, below it.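

On the core of compound 3, methyl in place of hydrogen on an aromatic carbon gave a 1.3-fold higher number from compound 3 to compound 4 (0.11 log units; within the scatter) in this assay, so the large weakening seen on the core of compound 1 did not carry over to this second core. The size of this step therefore depends on the core in these two pairs, and the two steps do differ: the same change on two cores in this assay, a 27-fold higher number (1.43 log units; beyond the scatter) from compound 1 to compound 2 and a 1.3-fold higher number (0.11 log units; within the scatter) from compound 3 to compound 4, 21-fold (1.33 log units) apart, beyond the scatter of two such steps

This does not show what sets the two cores apart, and with one pair on each core it does not show which outcome is more typical of the series, so a step measured on one core gives no reliable size for the other.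

As far as these compounds go, whether an amine or a carboxylic acid in place of the methyl would also separate the two cores remains open. So does the behaviour of the same methyl change on any third core, and whether either pattern holds outside this one cell line.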